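Replacing the acid of compound 2 with a methylamide

The source may report more compounds than this note shows. Statements on the series, on what has been measured and on what is new or still open speak of the compounds shown alone.

Of the compounds shown here, three have been measured in a functional assay on CHO cells for agonist activity at Free fatty acid receptor 1 (Homo sapiens), read by a luciferase reporter (a higher number here means a larger maximal response, a lower number a smaller maximal response), so far. Compound 1 `Cc1nc(-c2ccc(C(F)(F)F)cc2)sc1CNc1ccc(CCCC(=O)O)cc1` gives 44%. Compound 3 `Cc1nc(-c2ccc(C(F)(F)F)cc2)sc1CNc1ccc(OCC(=O)O)cc1` gives 100%. Compound 2 `O=C(O)/C=C/c1ccc(NCc2cccc(Oc3ccccc3)c2)cc1` gives 76%, which places it second highest of the three: compound 3 lies a step beyond the scatter above it, and compound 1 a step beyond the scatter below it.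

Within the data shown here, the only step measured within this set, a number 56 percentage points higher from compound 1 to compound 3 (beyond the scatter), keeps a carboxylic acid in place and only alters the chain that carries it, so it bears on the new change only loosely.

Compound 4 `CNC(=O)CCc1ccc(NCc2cccc(Oc3ccccc3)c2)cc1` differs from compound 2 in one respect: 2-(methylcarbamoyl)ethyl in place of 2-carboxyethenyl on an aromatic carbon. Here the carboxylic acid itself is gone, which no measured pair covers. With all three measured compounds carrying an acid and the largest response reached sitting with compound 3, a downward step is expected, and a large one; compound 4 is estimated to give 20%, with a range from 0% to 55%, so that the expected step is a number 56 percentage points lower from compound 2 to compound 4 (beyond the scatter).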

Compound 4, largest response reached (reported as percent of maximum), in percent of the reference or control that the assay uses: 67%
Estimate against measurement, compound 4: 47 percentage points below; measured number above the stated range.
By their numbers in this assay, from the lowest: compound 1; then compounds 4 and 2 (each within the scatter of the next); then compound 3.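

With this assay as the read-out, the step is a number 9 percentage points lower from compound 2 to compound 4 (within the scatter), so these two compounds cannot be told apart, even though compound 4 has no carboxylic acid. For this core and this position, then, a carboxylic acid is not required for a large maximal response, at least when a 2-(methylcarbamoyl)ethyl group takes its place. The swap also removes the chain's double bond outside the aromatic ring, and no measurement available here explains why the response shows no step beyond the scatter.

A saturated 2-carboxyethyl chain on the same core would separate the loss of that double bond from the replacement of the acid by the amide. Going by these compounds, it also remains open whether a methylamide could stand in for the carboxymethoxy group on the core of compound 3.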